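This account rests on a few compounds, and the source may have more. Where it says the series, first, only, none or still open, it means among the compounds named here.

Working notes on the series.

Compound 1, `CCCn1cnc2c(N(C)C)ncnc21`, is the reference point. In a functional assay on the whole organism for antagonist activity, with Rattus norvegicus as the target (a lower number here means that less compound is needed, a higher number that more compound is needed for the effect), compound 1 gives 15 mg/kg. Compound 2, `CC(C)Cn1cnc2c(N(C)C)ncnc21`, carries the change (methyl in place of hydrogen on a saturated chain carbon bound to two saturated chain carbons); in this assay compound 2 gives 22 mg/kg. Among the measured compounds shown here, the step of a 1.5-fold higher number from compound 1 to compound 2 (0.17 log units; within the scatter) is the only measured example of this kind of change in the set.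

Compound 3, `O=CN(c1ncnc2c1ncn2CC1CC1)C1CC1`, has a different core; how the core of compound 1 and the core of compound 3 differ is not broken down here. In this assay compound 3 gives 30 mg/kg, which sits within the scatter of the numbers for compound 1 and compound 2, so no order among the three is claimed.

Compound 4, `CC(C1CC1)n1cnc2c(N(C=O)C3CC3)ncnc21`, is not yet measured. It differs from compound 3 by methyl in place of hydrogen on a saturated chain carbon bound to an aromatic nitrogen and a saturated ring carbon. For the measured compounds named here, this is the same kind of change as the one from compound 1 to compound 2, but not the same: there the methyl entered on a saturated chain carbon bound to two saturated chain carbons, here it enters on a saturated chain carbon bound to an aromatic nitrogen and a saturated ring carbon. Going by the values given here, with only one measured example, the expectation rests on the step of a 1.5-fold higher number from compound 1 to compound 2 (0.17 log units; within the scatter) from compound 1 to compound 2, which stayed within the scatter; a step of similar size, a 1.3-fold higher number from compound 3 to compound 4 (0.12 log units; within the scatter), is expected from compound 3 to compound 4, with added uncertainty for the different surroundings. Compound 4 is therefore estimated at 40 mg/kg in this assay, with a likely range from 20 mg/kg to 90 mg/kg.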

Compound 4, dose for half-maximal effect: 7.5 mg/kg
Compound 4: the middle estimate sits 5.3-fold (0.73 log units) above what was measured; the measured number lies below the stated range.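

In this assay, methyl in place of hydrogen on a saturated chain carbon bound to an aromatic nitrogen and a saturated ring carbon, which turns cyclopropylmethyl into 1-cyclopropylethyl, gives a 4.0-fold lower number from compound 3 to compound 4 (0.60 log units; beyond the scatter). Set beside the earlier step, this methyl change does not carry over from one core to the other with the same size or direction: the same change on two cores in this assay, a 1.5-fold higher number (0.17 log units; within the scatter) from compound 1 to compound 2 and a 4.0-fold lower number (0.60 log units; beyond the scatter) from compound 3 to compound 4, 5.9-fold (0.77 log units) apart, beyond the scatter of two such steps. This does not show what governs the difference, as the two steps differ in both the core and the surroundings of the methyl, and a single pair on each core cannot separate these two differences or support a rule for the series.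

The compounds shown leave open whether 1-cyclopropylethyl on the core of compound 1 would give a step like the one seen on the core of compound 3, which would test the core apart from the surroundings of the methyl. They also leave open whether an ethyl group in place of this methyl on the same saturated chain carbon would continue the step seen here or reverse it.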